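Moving the nitro group to the para position of compound 1

The compounds below may be only part of what the source reports. "The series", "measured", "known", "first", "only" and "open" are said of these compounds alone.

Compound 1 `CC(=O)N1N=C(c2ccc3ccccc3c2)OC1c1ccccc1Br` sits second highest of the three measured numbers in a functional assay on MCF7 cells (Homo sapiens) for antiproliferative activity, read by MTT assay, with a stated time of 48 h (a lower number here means a stronger inhibitor, a higher number a weaker inhibitor), where compound 1 gives 5.49 ug/mL. Compound 2 `CC(=O)N1N=C(c2ccc3ccccc3c2)OC1c1cccc(Br)c1` gives 2.34 ug/mL and compound 3 `CC(=O)N1N=C(c2ccc3ccccc3c2)OC1c1ccccc1[N+](=O)[O-]` gives 18.2 ug/mL. The change to compound 4 `CC(=O)N1N=C(c2ccc3ccccc3c2)OC1c1ccc([N+](=O)[O-])cc1` is 4-nitrophenyl in place of 2-bromophenyl on a saturated ring carbon. For the measured compounds named here, two measured steps bear on it: exchanging bromo for nitro weakened inhibition, a 3.3-fold higher number from compound 1 to compound 3 (0.52 log units; beyond the scatter), while shifting the bromine from the 2- to the 3-position strengthened it, a 2.3-fold lower number from compound 1 to compound 2 (0.37 log units; beyond the scatter). Both effects are modest and pull in opposite directions, so compound 4 is expected to land somewhat above compound 1, as a weaker inhibitor, with an expected step of a 1.8-fold higher number from compound 1 to compound 4 (0.26 log units; within the scatter). The estimated value for compound 4 is 10 ug/mL, within a range from 4 ug/mL to 25 ug/mL.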

Compound 4, half-maximal inhibitory concentration: 7.59 ug/mL
Estimate against measurement, compound 4: 1.3-fold (0.12 log units) above, and the stated range covers the measured number.
By their numbers in this assay, from the lowest: compound 2; then compounds 1 and 4 (each within the scatter of the next); then compound 3.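

Where the nitro group sits on this phenyl ring matters: 4-nitrophenyl in place of 2-nitrophenyl brings the number down (a 2.4-fold lower number from compound 3 to compound 4 (0.38 log units; beyond the scatter)), so nitro as such does not carry a loss. Exchanging 2-bromophenyl for 4-nitrophenyl causes no change beyond the scatter (a 1.4-fold higher number from compound 1 to compound 4 (0.14 log units; within the scatter)), whereas 3-bromophenyl keeps a clear edge over 4-nitrophenyl (a 3.2-fold higher number from compound 2 to compound 4 (0.51 log units; beyond the scatter)). Nothing available here accounts for these differences. Still open, on these data alone, is how an amine or a carboxylic acid in place of the nitro group of compound 4 would read.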